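Series notes: isopropyl for hydrogen, compound 2 to compound 3

The compounds below may be only part of what the source reports. "The series", "measured", "known", "first", "only" and "open" are said of these compounds alone.

Measured so far:
compound 1 `CC(=O)c1ccc(NC(=O)CN(C(=O)c2ccccc2)S(=O)(=O)c2ccc(C)cc2)cc1`, 18.2%
compound 2 `CC(=O)c1ccc(NC(=O)CN(C(=O)c2ccccc2)S(=O)(=O)c2ccc([N+](=O)[O-])cc2)cc1`, 20.6%

In a functional assay for inhibition, read by spectrophotometry, with a stated time of 20 min, tested at 3 mg/mL (on this read-out lower numbers stand for a weaker effect and higher numbers for a stronger effect at the one concentration tested), compound 1 gives 18.2% and compound 2 gives 20.6%. For the measured compounds named here, the single measured step, a number 2.4 percentage points higher from compound 1 to compound 2 (within the scatter), lies within the scatter, so compound 2 holds the higher of the two numbers only nominally and cannot be called the stronger of the pair.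

Compound 3 `CC(=O)c1ccc(NC(=O)C(C(C)C)N(C(=O)c2ccccc2)S(=O)(=O)c2ccc([N+](=O)[O-])cc2)cc1` differs from compound 2 by isopropyl in place of hydrogen on a saturated chain carbon bound to an amide-type nitrogen and a carbonyl carbon. Going by the values given here, no measured step bears on this site: the one step in hand concerns a swap on an aromatic carbon, not the saturated chain carbon, and it was itself within the scatter. The read-out of compound 2 is therefore the only anchor, and nothing in the data argues for a move in either direction.

Relative to compound 2 the expected step to compound 3 is a number 1.4 percentage points higher from compound 2 to compound 3 (within the scatter), within the scatter. Compound 3 is estimated at 22%, with a range from 8% to 40%.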

Compound 3, a percentage reported as inhibition, at one concentration (the size of the read-out at that concentration, not a potency): 29.8%
For compound 3 the middle estimate is 7.8 percentage points below the measured one; measured number inside the range.
By their numbers in this assay, from the lowest: compounds 1, 2 and 3 (each within the scatter of the next, the first and the last beyond it).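

For the compounds shown here, this is the first reading at the saturated chain carbon bound to an amide-type nitrogen and a carbonyl carbon; the earlier step concerned only an aromatic carbon. In this assay, isopropyl in place of hydrogen gives a number 9.2 percentage points higher from compound 2 to compound 3 (within the scatter), so this position accepts a group of 3 carbon atoms with no change that can be told from the scatter. No supporting measurement bears on how this change acts on the read-out.

One substituent at one concentration cannot show whether the position has any real influence on the read-out. As far as these compounds go, it remains open whether a methyl, a longer chain, an amine or a carboxylic acid on this carbon would give a step beyond the scatter.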